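Aryl swap on the ether chain carbon: compound 3

The compounds below may be only part of what the source reports. "The series", "measured", "known", "first", "only" and "open" are said of these compounds alone.

Among the measured compounds shown here, compound 2 `N[C@]1(C(=O)O)[C@H]2[C@@H](C[C@H]1OCc1cc(F)cc(F)c1)[C@]2(F)C(=O)O` gives 12.4 nM in an assay on CHO cells for binding affinity to metabotropic glutamate receptor 2 (Rattus norvegicus) (a lower number here means a stronger inhibitor, a higher number a weaker inhibitor), the highest of the two numbers so far; its nearest neighbour is compound 1 `N#Cc1cccc(CO[C@@H]2C[C@@H]3[C@H]([C@]2(N)C(=O)O)[C@@]3(F)C(=O)O)c1`, which in this assay gives 2.94 nM. For the measured compounds named here, the single measured step, a 4.2-fold higher number from compound 1 to compound 2 (0.63 log units; beyond the scatter), exchanged the aryl group on the saturated chain carbon bound to an oxygen on a saturated carbon, and it is the only step that bears on the next change. Compound 3 `N[C@]1(C(=O)O)[C@H]2[C@@H](C[C@H]1OCc1c(Cl)cccc1Cl)[C@]2(F)C(=O)O` differs from compound 2 by 2,6-dichlorophenyl in place of 3,5-difluorophenyl on a saturated chain carbon bound to an oxygen on a saturated carbon. The one measured exchange at this position moved the number beyond the scatter but only modestly, and nothing shown fixes the direction of a further exchange there. Compound 3 is therefore expected near 20 nM in this assay, within 5 nM to 80 nM, which amounts to an expected step of a 1.6-fold higher number from compound 2 to compound 3 (0.21 log units; within the scatter).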

Compound 3, inhibition constant: 4.3 nM
For compound 3 the middle estimate is 4.7-fold (0.67 log units) above the measured one; measured number outside the range, below it.
By their numbers in this assay, from the lowest: compounds 1 and 3 (each within the scatter of the next); then compound 2.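

In this assay, the 2,6-dichlorophenyl exchange on the saturated chain carbon bound to an oxygen on a saturated carbon gives a 2.9-fold lower number from compound 2 to compound 3 (0.46 log units; beyond the scatter), so the number at this place can fall as well as rise with the aryl group. Set against the 3-cyanophenyl group, the same exchange gives a 1.5-fold higher number from compound 1 to compound 3 (0.17 log units; within the scatter), so a nitrile is not required for a number in the range of compounds 1 and 3. Nothing available accounts for the difference between the two halogenated aryl groups.

The exchange from compound 2 to compound 3 alters the halogen and its ring places together, and the compounds shown do not separate these two changes. Also open, going by these compounds, is how an unsubstituted phenyl, a pyridine ring or a saturated cyclohexyl group would behave at this place.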